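Removing the Chloro Group from Compound 3

The source may report more compounds than this note shows. Statements on the series, on what has been measured and on what is new or still open speak of the compounds shown alone.

Three analogues sharing one core have been measured in an ADME assay on RAW264.7 cells (Mus musculus) for cytotoxicity; on this read-out lower numbers stand for stronger inhibition of growth and higher numbers for weaker inhibition of growth. Within the data shown here, compound 1 `CCOC(=O)c1sc(/N=C2\NC(=O)/C(=C3/C(=O)Nc4ccccc43)S2)nc1C` gives 125 ug/mL, and compound 2 `CCOC(=O)c1sc(/N=C2\NC(=O)/C(=C3/C(=O)N(C)c4ccccc43)S2)nc1C` gives 500 ug/mL; the only single-change comparison between them is a 4.0-fold higher number from compound 1 to compound 2 (0.60 log units; beyond the scatter). Compound 3 `CCOC(=O)c1sc(/N=C2\NC(=O)/C(=C3/C(=O)N(Cc4ccccc4)c4ccc(Cl)cc43)S2)nc1C` gives 62.5 ug/mL, the lowest of the three numbers, within the scatter of compound 1 and beyond it against compound 2. Compound 4 `CCOC(=O)c1sc(/N=C2\NC(=O)/C(=C3/C(=O)N(Cc4ccccc4)c4ccccc43)S2)nc1C` differs from compound 3 by hydrogen in place of chloro on an aromatic carbon. Among the measured compounds shown here, no measured step concerns a substituent on that aromatic ring, so nothing in the data points to a direction, and no step beyond the scatter is expected. Compound 4 is therefore estimated at 100 ug/mL (range 45 ug/mL to 250 ug/mL), an expected step of a 1.6-fold higher number from compound 3 to compound 4 (0.20 log units; within the scatter).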

Compound 4, concentration for 50% growth inhibition: 500 ug/mL
For compound 4 the middle estimate is 5.0-fold (0.70 log units) below the measured one; the whole stated range lies below it.
By their numbers in this assay, from the lowest: compounds 3 and 1 (each within the scatter of the next); then compounds 2 and 4 (each within the scatter of the next).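

In this assay, the position that looked free of any measured trend turns out to matter: hydrogen in place of chloro on this aromatic carbon gives an 8.0-fold higher number from compound 3 to compound 4 (0.90 log units; beyond the scatter). Without the chloro, benzyl in place of hydrogen on the amide-type nitrogen gives a 4.0-fold higher number from compound 1 to compound 4 (0.60 log units; beyond the scatter), the same direction as methyl there, and phenyl in place of hydrogen on the chain carbon gives no change at the digits printed from compound 2 to compound 4 (within the scatter), so benzyl and methyl stand level. Nothing measured on these compounds offers an explanation for the chloro step. The compounds shown leave open whether fluoro or methoxy on that aromatic carbon would act as chloro does, and whether chloro would give a similar step with hydrogen or methyl on the amide-type nitrogen.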